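This account rests on a few compounds, and the source may have more. Where it says the series, first, only, none or still open, it means among the compounds named here.

Going by the values given here, in a functional assay on L1210 cells (Mus musculus) for antiproliferative activity (on this read-out lower numbers stand for stronger inhibition and higher numbers for weaker inhibition), compound 2 (`COc1cc(C(=O)c2sc(-c3ccncc3)cc2N)cc(OC)c1OC`) gives 1810 nM, the higher of the two numbers so far, while compound 1 (`COc1cc(C(=O)c2sc(-c3ccc(Br)cc3)cc2N)cc(OC)c1OC`) gives 100 nM. Compound 3 (`COc1cc(C(=O)c2sc(-c3ccccc3Cl)cc2N)cc(OC)c1OC`) has 2-chlorophenyl in place of pyridin-4-yl on an aromatic carbon. Among the compounds with values here, one measured step bears on this, the large change an 18-fold higher number from compound 1 to compound 2 (1.26 log units; beyond the scatter), which came with pyridin-4-yl replacing 4-bromophenyl. Returning to a halogen-bearing phenyl should undo much of that step, so a sizeable move to lower numbers is expected in this assay. The expected change is a 6.0-fold lower number from compound 2 to compound 3 (0.78 log units; beyond the scatter). Compound 3 is estimated at 300 nM, with an expected range of 80 nM to 1200 nM.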

Compound 3, half-maximal inhibitory concentration: 20 nM
Compound 3: middle estimate off by 15-fold (1.18 log units), on the high side, outside the stated range (below it).
By their numbers in this assay, from the lowest: compound 3; then compound 1; then compound 2.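

In this assay, a phenyl ring with a halogen on this carbon next to the ring sulfur does more than recover the earlier loss: 2-chlorophenyl gives a 91-fold lower number from compound 2 to compound 3 (1.96 log units; beyond the scatter). It also improves on 4-bromophenyl, with a 5.0-fold lower number from compound 1 to compound 3 (0.70 log units; beyond the scatter), although that step changes both the halogen and where it sits on the phenyl ring. No measurement here gives a reason for either step. Still open, from the compounds shown here alone, is which of those two changes carries the gain, something 4-chlorophenyl or 2-bromophenyl could separate. Plain phenyl would show what the halogen contributes at all.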